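This account rests on a few compounds, and the source may have more. Where it says the series, first, only, none or still open, it means among the compounds named here.

Measured in an assay on CHO cells for displacement of a labelled ligand from adenosine receptor A3 (Homo sapiens), read by scintillation counting, with a stated time of 60 min; on this read-out lower numbers stand for stronger inhibition and higher numbers for weaker inhibition:
compound 1 `CNC(=O)[C@@]12C[C@@H]1[C@@H](n1cnc3c(NC)nc(C#Cc4cccnc4)nc31)[C@H](O)[C@@H]2O` gives 2.15 nM
compound 2 `CNC(=O)[C@@]12C[C@@H]1[C@@H](n1cnc3c(NC)nc(C#Cc4ncccn4)nc31)[C@H](O)[C@@H]2O` gives 1.97 nM
compound 3 `CNC(=O)[C@@]12C[C@@H]1[C@@H](n1cnc3c(NC)nc(C#Cc4cc(C)c(C)o4)nc31)[C@H](O)[C@@H]2O` gives 1.45 nM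

Compound 3 holds the lowest of the three numbers in this assay, but its gaps to compound 2 and to compound 1 are within the scatter, so the three compounds stand level on this read-out. Compound 4 `CNC(=O)[C@@]12C[C@@H]1[C@@H](n1cnc3c(NC)nc(C#Cc4ccsc4)nc31)[C@H](O)[C@@H]2O` is not yet measured; it differs from compound 3 in one place: thiophen-3-yl in place of 4,5-dimethylfuran-2-yl on a triple-bonded carbon. Every measured step in the set exchanges the group on this same triple-bonded carbon: a 1.1-fold lower number from compound 1 to compound 2 (0.04 log units; within the scatter), a 1.5-fold lower number from compound 1 to compound 3 (0.17 log units; within the scatter) and a 1.4-fold lower number from compound 2 to compound 3 (0.13 log units; within the scatter). None of them moved the number beyond the scatter, whichever ring sat there. The change to thiophen-3-yl is one more exchange of that kind, so no step beyond the scatter is expected in this assay in either direction. For compound 4 the expected step is a 1.2-fold higher number from compound 3 to compound 4 (0.09 log units; within the scatter). Compound 4 is therefore estimated at 1.8 nM in this assay, with a range from 0.9 nM to 3.6 nM.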

Compound 4, inhibition constant: 0.52 nM
Compound 4: middle estimate off by 3.5-fold (0.54 log units), on the high side; measured number outside the range, below it.
By their numbers in this assay, from the lowest: compound 4; then compounds 3, 2 and 1 (each within the scatter of the next).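

In this assay, within the data shown here, thiophen-3-yl is the first group on this triple-bonded carbon to move the number beyond the scatter: a 2.8-fold lower number from compound 3 to compound 4 (0.45 log units; beyond the scatter), a 3.8-fold lower number from compound 2 to compound 4 (0.58 log units; beyond the scatter) and a 4.1-fold lower number from compound 1 to compound 4 (0.62 log units; beyond the scatter). The position is therefore not indifferent to the group it carries, even though these steps are modest and compounds 1, 2 and 3 stand level with one another. Nothing in hand bears on why thiophen-3-yl parts from the other three rings.

Open, on these data alone, is whether the lower number belongs to thiophen-3-yl alone or extends to thiophen-2-yl or a methyl-substituted thiophene. Also open, as far as these compounds go, is how the number responds when the ring on the triple-bonded carbon gives way to a non-aromatic group, such as an aminoalkyl chain or a carboxylic acid.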